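This account rests on a few compounds, and the source may have more. Where it says the series, first, only, none or still open, it means among the compounds named here.

Measured so far:
Compound 1, `COc1cc(-c2cc(/C=C/C(=O)c3ccc(N)cc3)[nH]n2)cc(OC)c1OC`, gives -38% in a functional assay on HT-29 cells (Homo sapiens) for cytotoxicity, read by sulforhodamine B assay, with a stated time of 48 h, tested at 10 uM; a lower number here means a stronger effect, a higher number a weaker effect of the compound at the concentration tested.
Compound 2, `COc1cc(-c2cc(/C=C/C(=O)c3ccc(Cl)c(Cl)c3)[nH]n2)cc(OC)c1OC`, gives 53% in this assay.

Compound 2 stands as the higher of these two numbers, the weaker effect, with compound 1 as its nearest neighbour far below it. The step from compound 2 leads to compound 3, `COc1ccc(C(=O)/C=C/c2cc(-c3cc(OC)c(OC)c(OC)c3)n[nH]2)cc1OC`, by the change (3,4-dimethoxyphenyl in place of 3,4-dichlorophenyl on a carbonyl carbon). Among the measured compounds shown here, the one measured step, a number 91 percentage points higher from compound 1 to compound 2 (beyond the scatter), changes the same place but with a different group, so it only shows how much this position can move the read-out; nothing measured tells whether a methoxy-bearing ring lands nearer compound 1 or compound 2. The expected step is therefore uncertain in direction, a number 33 percentage points lower from compound 2 to compound 3 (beyond the scatter). Compound 3 is estimated at 20%, within -30% to 65%.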

Compound 3, a percentage reported as activity, at one concentration (the size of the read-out at that concentration, not a potency): -94%
For compound 3 the middle estimate is 114 percentage points above the measured one; the whole stated range lies above it.
By their numbers in this assay, from the lowest: compound 3; then compound 1; then compound 2.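

At this position on the carbonyl carbon, 3,4-dimethoxyphenyl in place of 3,4-dichlorophenyl gives a number 147 percentage points lower from compound 2 to compound 3 (beyond the scatter) in this assay and so moves the read-out even further than the earlier change did. In place of 4-aminophenyl, it gives a number 56 percentage points lower from compound 1 to compound 3 (beyond the scatter) and so shows that 4-aminophenyl did not mark the strongest effect reachable here. Nothing available explains why this ring gives the strongest effect of the three compounds.

On these data alone, it remains open whether both methoxy groups matter, which a phenyl ring with a single methoxy group could address. As far as these compounds go, how an unsubstituted phenyl ring or a ring carrying a carboxylic acid would behave also remains unknown.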